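The source may report more compounds than this note shows. Statements on the series, on what has been measured and on what is new or still open speak of the compounds shown alone.

Measured so far:
compound 1 `COc1ccc(NC(=O)C2(C(=O)Nc3ccc(Nc4ncc5cc(C(=O)N(C)C)n(C6CCCC6)c5n4)cc3)CC2)cc1`: 96.1%
compound 2 `CN(C)C(=O)c1cc2cnc(Nc3ccc(NC(=O)C4(C(=O)Nc5ccc(Br)cc5)CC4)cc3)nc2n1C1CCCC1`: 94.3%

Both values come from a functional assay on T47D cells (Homo sapiens) for inhibition, read by CCK-8 assay, with a stated time of 72 h, tested at 10 uM; on this read-out higher numbers stand for more inhibition of growth at the one concentration tested and lower numbers for less inhibition of growth. Going by the values given here, compound 2, at 94.3%, stands within the scatter of compound 1, the only other measured member of the series, so the two cannot be ranked. Both numbers lie close to complete inhibition of growth, which leaves little room for any further rise.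

Next is compound 3 `Cc1ccc(NC(=O)C2(C(=O)Nc3ccc(Nc4ncc5cc(C(=O)N(C)C)n(C6CCCC6)c5n4)cc3)CC2)cc1`. The change is methyl in place of bromo on an aromatic carbon, in words methyl in place of bromo on an aromatic carbon. Among the compounds with values here, only one measured step bears on it, made at the same aromatic carbon: bromo in place of methoxy gave a number 1.8 percentage points lower from compound 1 to compound 2 (within the scatter). That single step is the whole basis for expecting no step beyond the scatter in this assay. Within the data shown here, no measured compound yet carries methyl at this place, so the expectation remains thinly supported.

For compound 3 the expected value is 94%, with an estimated range of 84% to 100%. The estimate corresponds to an expected a number 0.3 percentage points lower from compound 2 to compound 3 (within the scatter).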

Compound 3, percent growth inhibition at one concentration: 99.6%
Estimate against measurement, compound 3: 5.6 percentage points below; measured number inside the range.
By their numbers in this assay, from the lowest: compounds 2, 1 and 3 (each within the scatter of the next).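

In this assay methyl in place of bromo gives a number 5.3 percentage points higher from compound 2 to compound 3 (within the scatter) and methyl in place of methoxy gives a number 3.5 percentage points higher from compound 1 to compound 3 (within the scatter) on the same aromatic carbon of the six-membered ring. Together with the earlier bromo-for-methoxy step, this places methoxy, bromo and methyl all within the scatter of one another, so three different groups at this place on the shared core cannot be ranked, and all three compounds stand close to complete inhibition of growth at the one concentration tested. No measurement among the data bears on why the three values agree.

As far as these compounds go, a group of another kind at this carbon, such as an amine, a carboxylic acid or a longer chain like n-butyl, remains open, as does whether any such group would bring the number down from this level. Also open, from the compounds shown here alone, is whether compound 1, compound 2 and compound 3 would separate at lower concentrations, since a single-concentration read-out this close to complete inhibition gives little room for telling them apart.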